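The source may report more compounds than this note shows. Statements on the series, on what has been measured and on what is new or still open speak of the compounds shown alone.

Measured compounds:
- compound 1, `CCCC(C)n1c(CC)nc2c(-c3ccc(Cl)cc3Cl)nccc21`, 3 nM
- compound 2, `CCCC(C)n1c(CC)nc2c(-c3ccc(Cl)cc3C)nccc21`, 9.1 nM
- compound 3, `CCc1nc2c(-c3ccc(Cl)cc3C)nccc2n1C(CC)C1CC1`, 14 nM

In an assay for binding affinity to Corticotropin releasing factor receptor (Rattus norvegicus) (on this read-out higher numbers stand for weaker inhibition and lower numbers for stronger inhibition), compound 2 stands second highest of the three numbers; its nearest neighbour is compound 3, at a 1.5-fold higher number from compound 2 to compound 3 (0.19 log units; within the scatter), a gap within the scatter, while compound 1 lies furthest off, at a 3.0-fold higher number from compound 1 to compound 2 (0.48 log units; beyond the scatter), a gap beyond the scatter.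

Compound 4, `CCCC(C)n1c(CC)nc2c(-c3ccc(OC(F)F)cc3C)nccc21`, differs from compound 2 in one place: difluoromethoxy in place of chloro on an aromatic carbon. Going by the values given here, the only measured step that touches this position is the one from compound 1 to compound 2, where methyl in place of chloro gave a 3.0-fold higher number from compound 1 to compound 2 (0.48 log units; beyond the scatter), a modest loss. The step from compound 2 to compound 3 changes a different part of the molecule and says little here. Replacing chloro at this spot has so far cost potency, so compound 4 is expected to lose a little as well, an estimated 1.6-fold higher number from compound 2 to compound 4 (0.22 log units; within the scatter), a step near the edge of the scatter. Compound 4 is therefore estimated at 15 nM, within a range of 4 nM to 60 nM.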

Compound 4, inhibition constant: 9 nM
Estimate against measurement, compound 4: 1.7-fold (0.22 log units) above; the range from low to high includes it.
By their numbers in this assay, from the lowest: compound 1; then compounds 4, 2 and 3 (each within the scatter of the next).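

In this assay, difluoromethoxy in place of chloro on the aromatic carbon para to a large group gives a 1.0-fold lower number from compound 2 to compound 4 (0.00 log units; within the scatter), so this position takes a group with more heavy atoms and a hydrogen-bond acceptor with no change that stands out from the scatter. Going by these compounds alone, the earlier loss, a 3.0-fold higher number from compound 1 to compound 2 (0.48 log units; beyond the scatter), came from replacing the other chloro, the one whose place the methyl group holds, so it says nothing direct about this position, and this is the first reading here. No measurement is available to explain this result.

An amine, a carboxylic acid or a longer chain such as butoxy at this position could show how far this tolerance extends. Also open, from the compounds shown here alone, is whether difluoromethoxy gives the same result alongside the 1-cyclopropylpropyl group of compound 3.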